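From compound 3 to compound 4: adding a methoxy

The source may hold more compounds than are shown below. What is called first, only, known or untested is meant among the compounds shown, and "the series" means these compounds.

Compound 1 (`O=C(CN1CCN(C(=O)c2ccccc2)CC1)N1CCN(CCCc2c[nH]c3ccccc23)CC1`) reads > 200000 nM in an ADME assay on HEK293 cells (Homo sapiens) for cytotoxicity, read by MTT assay, with a stated time of 72 h (on this read-out higher numbers stand for weaker inhibition and lower numbers for stronger inhibition), and that reading is a limit of the assay, not a number. Compound 2 (`O=C(CN1CCN(C(=O)c2cccc(F)c2)CC1)N1CCN(CCCc2c[nH]c3ccccc23)CC1`) and compound 3 (`O=C(CN1CCN(C(=O)c2ccccc2)CC1)N1CCN(CCCc2c[nH]c3ccc(F)cc23)CC1`) each carry one fluoro in place of hydrogen on an aromatic carbon, at different places. In this assay compound 2 gives 182000 nM while compound 3 gives 148000 nM and these two numbers lie within the scatter of each other, so compound 3 stands level with compound 2.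

Compound 4 (`COc1ccc(C(=O)N2CCN(CC(=O)N3CCN(CCCc4c[nH]c5ccc(F)cc45)CC3)CC2)cc1`) differs from compound 3 by one change, methoxy in place of hydrogen on an aromatic carbon, which turns a phenyl to 4-methoxyphenyl: methoxy in place of hydrogen on an aromatic carbon

Within the data shown here, no methoxy step has been measured here, so the nearest guides are the two fluoro swaps, one showing an at least 1.0-fold lower number from compound 1 to compound 2 (0.04 log units; that floor lies within the scatter) and the other showing an at least 1.3-fold lower number from compound 1 to compound 3 (0.13 log units; that floor lies within the scatter) as its size. Neither gives a sign of a step beyond the scatter, so none is expected in this assay in either direction, although fluoro is only a loose guide to methoxy. The estimate for this change is a 1.0-fold higher number from compound 3 to compound 4 (0.01 log units; within the scatter) and no more than that is expected. The estimated value for compound 4 is 150000 nM within a range from 80000 nM to 200000 nM and a reading that is only a limit remains possible.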

Compound 4, half-maximal inhibitory concentration: 141000 nM
For compound 4 the middle estimate is 1.1-fold (0.03 log units) above the measured one, within the range that was stated.
By their numbers in this assay, from the lowest: compounds 4, 3 and 2 (each within the scatter of the next). At a limit, above all of these: compound 1.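

Until now, the only substituent shown on an aromatic carbon was fluoro, a single atom in place of hydrogen. Compound 4 brings a larger group to this ring: methoxy, with 2 heavy atoms and 1 hydrogen-bond acceptor, para to a large group. This change gives a 1.0-fold lower number from compound 3 to compound 4 (0.02 log units; within the scatter) in this assay, so at this position in this series, methoxy produces no step that can be told apart from the scatter, and compound 4 still gives a real number, while the top of the measurable range stays close to these values: the limit of > 200000 nM in this assay, at which 1 of the 4 values shown sits.

What the compounds shown leave open is whether a different kind of group at this place, such as an amine, a carboxylic acid or a longer chain like butoxy, would also stay within the scatter in this assay and still give a number rather than a limit. They also leave open whether methoxy on another carbon of this ring, or on the core of compound 1 without the fluoro, would behave the same way.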